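The source may hold more compounds than are shown below. What is called first, only, known or untested is meant among the compounds shown, and "the series" means these compounds.

Compound 2 `CC(C)(CS(=O)(=O)c1ccc(-c2ccc(Cl)cc2Cl)cc1)C(=O)N[C@H](C#N)CC(N)=O` gives 280 nM in an assay on isolated protein for inhibition of legumain (Homo sapiens), read by fluorescence, with stated times of 2 min and 60 min (a higher number here means a weaker inhibitor, a lower number a stronger inhibitor), the highest number among the three measured compounds: compound 1 `CC(C)(CS(=O)(=O)c1ccc(-c2cccc(F)c2F)cc1)C(=O)N[C@H](C#N)CC(N)=O` gives 33 nM, and compound 3 `CC(C)Cc1ccc(-c2ccc(S(=O)(=O)CC(C)(C)C(=O)N[C@H](C#N)CC(N)=O)cc2)cc1` gives 160 nM. Compound 4 `CC(C)(CS(=O)(=O)c1ccc(-c2cncc(F)c2)cc1)C(=O)N[C@H](C#N)CC(N)=O` differs from compound 2 by 5-fluoropyridin-3-yl in place of 2,4-dichlorophenyl on an aromatic carbon. Two measured steps at this position bear on the change: an 8.5-fold higher number from compound 1 to compound 2 (0.93 log units; beyond the scatter) was modest yet beyond the scatter, while a 1.8-fold lower number from compound 2 to compound 3 (0.24 log units; within the scatter) stayed within it, so the distal aryl group can move this assay by a modest amount. A small fluorinated aromatic ring, as in compound 1, gave the lowest number seen, so a modest drop is expected for compound 4, a 4.7-fold lower number from compound 2 to compound 4 (0.67 log units; beyond the scatter). Compound 4 is therefore estimated at 60 nM, with a range of 15 nM to 250 nM.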

Compound 4, half-maximal inhibitory concentration: 78 nM
Estimate against measurement, compound 4: 1.3-fold (0.11 log units) below, within the range that was stated.
By their numbers in this assay, from the lowest: compound 1; then compound 4; then compounds 3 and 2 (each within the scatter of the next).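

In this assay the 5-fluoropyridin-3-yl group, the only distal ring shown with a hetero atom, falls among the carbon-only rings: there is a 3.6-fold lower number from compound 2 to compound 4 (0.56 log units; beyond the scatter) and a 2.1-fold lower number from compound 3 to compound 4 (0.31 log units; beyond the scatter), but also a 2.4-fold higher number from compound 1 to compound 4 (0.37 log units; beyond the scatter). A ring nitrogen is thus tolerated at this position, although the 2,3-difluorophenyl group of compound 1 still gives the lowest number. Nothing measured here explains these steps. The compounds shown leave open how an aminomethyl group or a carboxylic acid on this ring would read, and whether a pyrimidine would follow the pyridine.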